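From Methylsulfanyl to an Arylsulfanyl Group

The source may hold more compounds than are shown below. What is called first, only, known or untested is meant among the compounds shown, and "the series" means these compounds.

Compound 3 `CSc1cc(C)c(C(=O)N=C(N)N)cc1S(C)(=O)=O` gives 6 nM in a functional assay for inhibition of sodium/hydrogen exchanger (Oryctolagus cuniculus) (on this read-out higher numbers stand for weaker inhibition and lower numbers for stronger inhibition), the lowest number among the three measured compounds. Compound 1 `Cc1cc(-c2ccc(Cl)cc2)c(S(C)(=O)=O)cc1C(=O)N=C(N)N` gives 45 nM and compound 2 `Cc1cc(-c2ccc(Cl)cc2Cl)c(S(C)(=O)=O)cc1C(=O)N=C(N)N` gives 42 nM; a 1.1-fold lower number from compound 1 to compound 2 (0.03 log units; within the scatter). Compound 4 `Cc1cc(Sc2ccccc2Cl)c(S(C)(=O)=O)cc1C(=O)N=C(N)N` is not yet measured; it differs from compound 3 by 2-chlorophenyl in place of methyl on a sulfur. Going by the values given here, the steps that bear on it run the other way: a 7.5-fold lower number from compound 1 to compound 3 (0.88 log units; beyond the scatter), and a 7.0-fold lower number from compound 2 to compound 3 (0.85 log units; beyond the scatter). Those steps exchanged a directly attached aryl for methylsulfanyl, whereas here an aryl enters on the sulfur, so a step of the same size is not assured. The step expected is a 3.3-fold higher number from compound 3 to compound 4 (0.52 log units; beyond the scatter), a moderate rise. Compound 4 is therefore estimated at 20 nM, within 6 nM to 70 nM.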

Compound 4, half-maximal inhibitory concentration: 14 nM
Compound 4: the middle estimate sits 1.4-fold (0.15 log units) above what was measured; the measured number falls inside the stated range.
By their numbers in this assay, from the lowest: compound 3; then compound 4; then compounds 2 and 1 (each within the scatter of the next).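

In this assay, an aromatic ring on the sulfur brings only a modest rise over methyl (a 2.3-fold higher number from compound 3 to compound 4 (0.37 log units; beyond the scatter)), so this position accepts the larger (2-chlorophenyl)sulfanyl group. That group also gives lower numbers than either directly attached aryl (a 3.0-fold lower number from compound 2 to compound 4 (0.48 log units; beyond the scatter); a 3.2-fold lower number from compound 1 to compound 4 (0.51 log units; beyond the scatter)). No measurement offered here accounts for these steps. What the chlorine itself contributes stays open, since no unsubstituted phenyl on the sulfur appears among these compounds. On these data alone, whether an ethyl chain on the sulfur, or an amine in place of the sulfur, would fall nearer compound 3 also remains unknown.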